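The source may report more compounds than this note shows. Statements on the series, on what has been measured and on what is new or still open speak of the compounds shown alone.

Working notes on the series. In an ADME assay on liver for metabolic stability, with Liver microsome (Homo sapiens) as the target, read by LC-MS, using microsomes and NADPH, with a stated time of 30 min, tested at 1 uM (on this read-out lower numbers stand for a less stable compound and higher numbers for a more stable compound), compound 1 `CC(=O)OCc1cc(N)c(Nc2ccc(C#N)cc2)cc1Oc1c(C)cc(CCC#N)cc1C` gives 3%, compound 2 `COCc1cc(N)c(Nc2ccc(C#N)cc2)cc1Oc1c(C)cc(CCC#N)cc1C` gives 90.8% and compound 3 `COC(=O)c1cc(N)c(Nc2ccc(C#N)cc2)cc1Oc1c(Br)cc(CCC#N)cc1OC` gives 81.5%. Compound 3 thus stands second highest of the three: its gap to compound 2 lies within the scatter, its gap to compound 1 lies beyond it. Within the data shown here, the only measured step, a number 87.8 percentage points higher from compound 1 to compound 2 (beyond the scatter), concerns methyl in place of acetyl on an oxygen on a saturated carbon. Among the measured compounds shown here, compound 4 `CNC(=O)c1cc(N)c(Nc2ccc(C#N)cc2)cc1Oc1c(Br)cc(CCC#N)cc1OC` differs from compound 3 by methylamino in place of methoxy on a carbonyl carbon; no measured step covers this change, so the expectation rests on compound 3 alone. The expected step is a number 1.5 percentage points higher from compound 3 to compound 4 (within the scatter), not beyond the scatter. For compound 4 the estimate in this assay is 83%, between 60% and 97%.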

Compound 4, percent of the compound remaining in the Liver microsome assay: 75.7%
Compound 4: middle estimate off by 7.3 percentage points, on the high side, and the stated range covers the measured number.
By their numbers in the Liver microsome assay, from the lowest: compound 1; then compounds 4, 3 and 2 (each within the scatter of the next, the first and the last beyond it).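

In the Liver microsome assay the carbonyl carbon takes methylamino in place of methoxy with a number 5.8 percentage points lower from compound 3 to compound 4 (within the scatter), so methoxycarbonyl and methylcarbamoyl cannot be told apart on this read-out. Among these compounds, the earlier compounds showed only that a change on an oxygen on a saturated carbon can carry a large step, not that a change on this carbonyl carbon can pass without a readable one. In a physicochemical assay for solubility, read by HPLC, in phosphate buffer, with a stated time of 4 h, at pH 7.4, tested at 10 mg/mL (on this read-out higher numbers stand for higher solubility and lower numbers for lower solubility), compound 3 gives 0.2 ug/mL and compound 4 gives 3.38 ug/mL, and the same change does separate the two compounds: the measured solubility of compound 3, 0.2 ug/mL, and of compound 4, 3.38 ug/mL, a 17-fold higher number (1.23 log units; beyond the scatter)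

The compounds shown leave open how a carboxylic acid or a plain amino group on this carbonyl carbon would read on either measure. They also leave open whether methylamino in place of methoxy gives the same picture with the other substituents of compound 1 and compound 2.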